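A few compounds are considered here, and "the series" means these few. Any claim that something is new, unique, unknown or untested is made for them only; others in the source may bear on it.

Compound 1, `CCCCC[Se]c1nc(NCc2ccccc2)c2ccccc2n1`, gives 50 nM in a functional assay on MCF7 cells (Homo sapiens) for cytotoxicity, read by MTT assay, with a stated time of 72 h; a lower number here means a stronger inhibitor of growth, a higher number a weaker inhibitor of growth.
Compound 2, `CCCCCSc1nc(NCc2ccc([Se]C)cc2)c2ccccc2n1`, gives 13000 nM in this assay.
Compound 3, `CSc1nc(NCCCCCO)c2cccnc2n1`, gives 48900 nM in this assay.

Among these three numbers compound 2 stands second highest. The nearest value is that of compound 3, whose number is higher than that of compound 2 by a gap beyond the scatter. The furthest value is that of compound 1, whose number lies far lower than that of compound 2, again beyond the scatter. Compound 1 is thus the strongest inhibitor of growth in this set, and compound 3 the weakest.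

The unmeasured compound 4, `CSc1nc(NCc2ccc([Se]C)cc2)c2ccccc2n1`, is compound 2 with one change: hydrogen in place of butyl on a saturated chain carbon bound to a sulfur. For the measured compounds named here, no measured pair shows this change alone, so its effect is not known from the data. Going by the values given here, the only other compound carrying a methylsulfanyl group, compound 3, differs from compound 2 in its core and in its side chain as well, so it cannot isolate the step. With that in mind, the step from compound 2 to compound 4 in this assay is expected to be small, most likely toward a somewhat higher number, and may fall within the scatter, as a 1.9-fold higher number from compound 2 to compound 4 (0.28 log units; within the scatter) expresses. Compound 4 is therefore estimated at 25000 nM, within a range from 6000 nM to 100000 nM.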

Compound 4, concentration for 50% growth inhibition: 36400 nM
The estimate for compound 4 lay 1.5-fold (0.16 log units) below the measured number; the measured number falls inside the stated range.
By their numbers in this assay, from the lowest: compound 1; then compound 2; then compounds 4 and 3 (each within the scatter of the next).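

In this assay, for the compounds shown here, the change from pentylsulfanyl to methylsulfanyl gives a 2.8-fold higher number from compound 2 to compound 4 (0.45 log units; beyond the scatter) and is the first time this change can be seen alone, since the rest of the molecule is the same in both compounds. The step is modest but beyond the scatter, so at this place on the shared core the pentyl chain has a measurable link to growth inhibition, and the compound with the methyl group is the weaker inhibitor of the two. The data offer no measurement that explains why the number moves in this direction.

On these data alone, with only pentyl and methyl to compare at this place, it remains open whether the number changes steadily with chain length, which an ethyl, a propyl or a longer chain such as octyl could test, and whether a chain ending in an amine or a carboxylic acid would fit the same trend. As far as these compounds go, it also remains open whether the same shortening would give a step of similar size on a different core or in a compound with selenium rather than sulfur carrying the chain.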